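Swapping Cyano for Trifluoromethoxy at the Binding Limit

The source may hold more compounds than are shown below. What is called first, only, known or untested is meant among the compounds shown, and "the series" means these compounds.

Compound 3 `N#Cc1cccc(C[C@H](O)CC[C@H]2CCC(=O)N2CCCCCCC(=O)O)c1` was tested in an assay on HEK293 cells for binding affinity to prostaglandin E2 receptor EP2 subtype (Rattus norvegicus); on this read-out higher numbers stand for weaker inhibition and lower numbers for stronger inhibition. In this assay compound 3 gives > 3200 nM, which is a limit of the assay rather than a number. Compound 1 `O=C(O)CCCCCCN1C(=O)CC[C@@H]1CC[C@@H](O)CCc1ccccc1` likewise gives > 3200 nM, again a limit. Compound 2 `O=C(O)CCCCCCN1C(=O)CC[C@@H]1CC[C@@H](O)Cc1cccc(-c2ccccc2)c1` gives > 3200 nM, also a limit. The steps a step that the two limits leave unreadable from compound 1 to compound 3 and a step that the two limits leave unreadable from compound 2 to compound 3 are therefore unreadable in size, as the limit of > 3200 nM in this assay, at which 3 of the 3 values shown sit, records for every value shown.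

Compound 4 `O=C(O)CCCCCCN1C(=O)CC[C@@H]1CC[C@@H](O)Cc1cccc(OC(F)(F)F)c1` differs from compound 3 by trifluoromethoxy in place of cyano on an aromatic carbon. Among the compounds with values here, no measured step gives a readable size for this kind of change. The step that the limit leaves unreadable from compound 3 to compound 4 is expected to stay within the usual scatter. Compound 4 is estimated at 5000 nM, within a range from 1500 nM to 20000 nM.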

Compound 4, half-maximal inhibitory concentration: > 3200 nM
Compound 4: only a limit was reported; the forecaster's own chance of this, stated with the estimate: 70%; the middle value lies beyond the limit too.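

No size can be read for the steps from compound 3 or compound 2 to compound 4, because these compounds all sit at the same limit: the limit of > 3200 nM in this assay, at which 4 of the 4 values shown sit.

The compounds shown leave open whether any of these aromatic groups differ in binding at all.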